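Swapping the benzyl substituent on the amine of compound 2

This account rests on a few compounds, and the source may have more. Where it says the series, first, only, none or still open, it means among the compounds named here.

Compound 2 `COc1cc(NCc2cccc(O)c2)cc(OC)c1OC` gives 71300 nM in a functional assay on KYSE-450 cells (Homo sapiens) for inhibition, read by MTT assay, with a stated time of 48 h (a higher number here means a weaker inhibitor, a lower number a stronger inhibitor), the higher of the two numbers seen; compound 1 `C/C=C/C(=O)N(Cc1cccc(O)c1)c1cc(OC)c(OC)c(OC)c1` gives 14700 nM. Among the measured compounds shown here, the one known step, a 4.9-fold higher number from compound 1 to compound 2 (0.69 log units; beyond the scatter), concerns a change at the nitrogen and not the ring being swapped here. Compound 3 `COc1cc(NCc2ccc(C)cc2)cc(OC)c1OC` differs from compound 2 by 4-methylphenyl in place of 3-hydroxyphenyl on a saturated chain carbon bound to a nitrogen on an aromatic ring. For the measured compounds named here, no measured step speaks to this change, so no shift beyond the scatter is expected: a 1.2-fold lower number from compound 2 to compound 3 (0.07 log units; within the scatter). Compound 3 is therefore estimated at 60000 nM, within a range of 20000 nM to 180000 nM.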

Compound 3, half-maximal inhibitory concentration: > 80000 nM
Compound 3 ended at the assay's limit; the forecaster's own chance of this, stated with the estimate: 25%; middle value at least 1.3-fold (0.12 log units) away from the limit.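

In this assay compound 3 gives > 80000 nM, which is a limit of the assay and not a number: the limit of > 80000 nM in this assay, at which 1 of the 3 values shown sits. As far as these compounds go, the change therefore reads only as an at least 1.1-fold higher number from compound 2 to compound 3 (0.05 log units; that floor lies within the scatter), so no gain appears from 4-methylphenyl on this saturated chain carbon, while the size of any loss stays unknown.

The compounds shown do not separate losing the hydroxyl from adding the methyl. An amine or a carboxylic acid on this ring, or the same swap on compound 1, could show whether this position responds at all.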